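Ester cleavage to the free acid in a kinase series

This account rests on a few compounds, and the source may have more. Where it says the series, first, only, none or still open, it means among the compounds named here.

Measured so far in an assay on isolated protein for inhibition of Rho-associated protein kinase 2 (Homo sapiens), read by radiometric assay; on this read-out lower numbers stand for stronger inhibition and higher numbers for weaker inhibition: compound 1 `NCc1ccc(C(=O)Nc2ccncc2F)cc1-c1cccc(C(=O)OCC2CC2)c1` gives 2.7 nM; compound 2 `NCc1ccc(C(=O)Nc2ccncc2)cc1-c1cccc(C(=O)OCc2ccccc2)c1` gives 45 nM; compound 3 `CCCCCOC(=O)c1cccc(-c2cc(C(=O)Nc3ccncc3)ccc2CN)c1` gives 4.9 nM.

Compound 1 has the lowest number of the three, with compound 3 within the scatter of it and compound 2 clearly higher. Compound 4 `NCc1ccc(C(=O)Nc2ccncc2F)cc1-c1cccc(C(=O)O)c1` differs from compound 1 by hydrogen in place of cyclopropylmethyl on an oxygen next to a carbonyl group. For the measured compounds named here, no measured step removes the group on the oxygen next to a carbonyl group entirely; the only change at that oxygen, a 9.2-fold lower number from compound 2 to compound 3 (0.96 log units; beyond the scatter), shows that what sits there can shift this assay markedly. A weaker number for compound 4 is therefore expected, with wide uncertainty: compound 4 is estimated at 30 nM (range 5 nM to 300 nM), a step of an 11-fold higher number from compound 1 to compound 4 (1.05 log units; beyond the scatter).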

Compound 4, half-maximal inhibitory concentration: 55 nM
The estimate for compound 4 lay 1.8-fold (0.26 log units) below the measured number; the measured number falls inside the stated range.
By their numbers in this assay, from the lowest: compounds 1 and 3 (each within the scatter of the next); then compounds 2 and 4 (each within the scatter of the next).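

Hydrogen in place of cyclopropylmethyl on an oxygen next to a carbonyl group gives a 20-fold higher number from compound 1 to compound 4 (1.31 log units; beyond the scatter), the only step shown that leaves this oxygen without a carbon group. The free acid compound 4 still reads 55 nM, so inhibition at this level does not depend on an ester group here. Nothing measured on these compounds accounts for the size of this step.

Open, as far as these compounds go, is where a methyl ester, a primary amide or a tetrazole in place of the carboxy group would fall relative to compound 1 and compound 4.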